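This account rests on a few compounds, and the source may have more. Where it says the series, first, only, none or still open, it means among the compounds named here.

Compound 3, `NCc1ccc(C(=O)Nc2cccc(NC(=O)COc3ccc4c(=O)ccoc4c3)c2)cc1`, is the weakest of the three measured compounds in an assay on isolated protein for inhibition of Rho-associated protein kinase 2 (Homo sapiens), read by scintillation counting, radiometric assay and 33P incorporation, with a stated time of 40 min, in the presence of a further agent that is not named here (a higher number here means a weaker inhibitor, a lower number a stronger inhibitor), where compound 3 gives 66 nM. Compound 1, `N#Cc1ccc(C(=O)Nc2cccc(NC(=O)COc3ccc4c(=O)ccoc4c3)c2)cc1`, gives 15 nM in this assay, and compound 2, `CC(C)(C)c1cc(C(=O)Nc2cccc(NC(=O)COc3ccc4c(=O)ccoc4c3)c2)no1`, gives 5 nM; the steps of a 4.4-fold higher number from compound 1 to compound 3 (0.64 log units; beyond the scatter) and a 13-fold higher number from compound 2 to compound 3 (1.12 log units; beyond the scatter) are both beyond the scatter, and the step of a 3.0-fold lower number from compound 1 to compound 2 (0.48 log units; beyond the scatter) is modest.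

Compound 4, `O=C(COc1ccc2c(=O)ccoc2c1)Nc1cccc(NC(=O)c2ccc(C(=O)O)cc2)c1`, differs from compound 3 by carboxy in place of aminomethyl on an aromatic carbon. Among the compounds with values here, the only measured step that touches the same position is a 4.4-fold higher number from compound 1 to compound 3 (0.64 log units; beyond the scatter), a modest change when cyano became aminomethyl; nothing measured here shows a carboxy group at that place, so the direction of the new step cannot be read from any measured pair. The other two steps concern the group on the carbonyl carbon and say little about this change. A step of modest size in either direction, or none beyond the scatter, is therefore the expectation for this assay.

On that basis compound 4 is expected to give about 80 nM in this assay, within a range of 25 nM to 300 nM, which would mean an expected step of a 1.2-fold higher number from compound 3 to compound 4 (0.08 log units; within the scatter).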

Compound 4, half-maximal inhibitory concentration: 2030 nM
Compound 4: the middle estimate sits 25-fold (1.40 log units) below what was measured, outside the stated range (above it).
By their numbers in this assay, from the lowest: compound 2; then compound 1; then compound 3; then compound 4.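

Among the groups seen at this place, para to a large group on the six-membered aromatic ring, the earlier compounds showed only a modest spread, whereas the carboxy group brings a large change: in this assay the result is a 31-fold higher number from compound 3 to compound 4 (1.49 log units; beyond the scatter) when carboxy replaces aminomethyl, and a 140-fold higher number from compound 1 to compound 4 (2.13 log units; beyond the scatter) when it replaces cyano. This position therefore tolerates some substituents far better than others, and the size of the change cannot be followed from the count of heavy atoms or of hydrogen-bond donors and acceptors, since aminomethyl and carboxy carry the same count of donors and of acceptors; replacing the whole 5-(tert-butyl)-1,2-oxazol-3-yl group with 4-carboxyphenyl gives the widest gap in the set, a 410-fold higher number from compound 2 to compound 4 (2.61 log units; beyond the scatter) in all, leaving compound 4 the weakest of the four. No measurement shown here explains why carboxy at this place has so large an effect.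

Going by these compounds, it remains open whether a methyl ester or a primary amide at this place would stay near compound 1 or fall toward compound 4. On these data alone, it is equally open whether a longer chain carrying the carboxylic acid, set further from the ring, would give the same large step.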